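The compounds below may be only part of what the source reports. "The series", "measured", "known", "first", "only" and "open" are said of these compounds alone.

Measured so far in a functional assay on PC-12 cells (Rattus norvegicus) for cytotoxicity, read by MTT assay, with stated times of 2 h and 24 h, tested at 10 uM; a lower number here means a weaker effect, a higher number a stronger effect of the compound at the concentration tested:
compound 1, `CC(C)c1ccc(-n2nc(-c3ccc(C(F)(F)F)cc3O)nc2-c2ccccc2O)cc1`: 108%
compound 2, `Oc1cc(C(F)(F)F)ccc1-c1nc(-c2ccccc2O)n(-c2ccc(OC(F)(F)F)cc2)n1`: 92.5%
compound 3, `Oc1cc(C(F)(F)F)ccc1-c1nc(-c2ccccc2O)n(-c2ccccc2Cl)n1`: 102%

Compound 3 stands second highest of the three numbers. Its nearest neighbour is compound 1, with a number 6 percentage points lower from compound 1 to compound 3 (within the scatter); its furthest is compound 2, with a number 9.5 percentage points higher from compound 2 to compound 3 (within the scatter). Within the data shown here, both gaps lie within the scatter, so the three compounds cannot be ordered against one another on this assay; only the step of a number 15.5 percentage points lower from compound 1 to compound 2 (beyond the scatter) reaches beyond it, and that one is modest.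

Compound 4, `Oc1cc(C(F)(F)F)ccc1-c1nc(-c2ccccc2O)n(-c2ccccc2C(F)(F)F)n1`, differs from compound 3 in one place: trifluoromethyl in place of chloro on an aromatic carbon. Among the measured compounds shown here, no measured step changes a group at this same position. The step from compound 1 to compound 2 exchanges one group for another on the same ring, and the two steps leading to compound 3 exchange the whole ring on the aromatic nitrogen; both of the latter stay within the scatter, and all three values sit in a narrow band near full effect. On that footing the change to compound 4 is expected to move the read-out little in this assay, with no clear direction. The expected step is therefore a number 3 percentage points lower from compound 3 to compound 4 (within the scatter), within the scatter. Compound 4 is estimated at 99%, in a range from 85% to 112%.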

Compound 4, a percentage reported as activity, at one concentration (the size of the read-out at that concentration, not a potency): 92.2%
Compound 4: the middle estimate sits 6.8 percentage points above what was measured; the measured number falls inside the stated range.
By their numbers in this assay, from the lowest: compounds 4, 2, 3 and 1 (each within the scatter of the next, the first and the last beyond it).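

In this assay, among these compounds, the exchange of chloro for trifluoromethyl on an aromatic carbon, ortho to a large group, is the first change at this position, and a number 9.8 percentage points lower from compound 3 to compound 4 (within the scatter) leaves it within the scatter, so this pair of groups is not separated here; a number 0.3 percentage points lower from compound 2 to compound 4 (within the scatter) likewise stays within the scatter, although that step exchanges the whole ring on the aromatic nitrogen. Among the compounds shown here, the only new step that passes the scatter is a number 15.8 percentage points lower from compound 1 to compound 4 (beyond the scatter), a modest step that, together with a number 15.5 percentage points lower from compound 1 to compound 2 (beyond the scatter), sets compound 1 apart from compound 2 and compound 4, while compound 3 goes against any such separation because its step from compound 1 stays within the scatter. No measurement at hand offers an explanation for these steps.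

Going by these compounds, whether a group of another kind on this aromatic carbon, such as an amine or a carboxylic acid, would carry the read-out beyond the scatter remains open. Also open, on these data alone, is how this assay would respond to a change in the shared core itself, for instance a methoxy group in place of either hydroxyl group.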